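Swapping the hydroxyphenyl arm on a bromo analogue

The source may hold more compounds than are shown below. What is called first, only, known or untested is meant among the compounds shown, and "the series" means these compounds.

Compound 2 `O=C1N=C(N2N=C(c3ccccc3)CC2c2ccccc2O)S/C1=C1/C(=O)Nc2ccc(Br)cc21` has the lower of the two numbers recorded so far in a functional assay on cells (Cancer cell lines, Homo sapiens) for cytotoxicity, read by sulforhodamine B assay, with a stated time of 48 h (a lower number here means a stronger inhibitor of growth, a higher number a weaker inhibitor of growth), where compound 2 gives 930 nM; compound 1 `O=C1N=C(N2N=C(c3ccccc3)CC2c2ccccc2O)S/C1=C1/C(=O)Nc2ccccc21` gives 4350 nM, and a 4.7-fold lower number from compound 1 to compound 2 (0.67 log units; beyond the scatter) separates them. Compound 3 `CN(C)c1ccc(C2CC(c3ccccc3)=NN2C2=NC(=O)/C(=C3\C(=O)Nc4ccc(Br)cc43)S2)cc1` differs from compound 2 by 4-(dimethylamino)phenyl in place of 2-hydroxyphenyl on a saturated ring carbon. Among the measured compounds shown here, no measured step touches this part of the shared core, since the only change recorded so far was bromo in place of hydrogen on an aromatic carbon, so the data give no direction for it. Compound 3 is therefore expected to stay close to this level, so that a 1.2-fold higher number from compound 2 to compound 3 (0.07 log units; within the scatter) should lie within the scatter. The estimate for compound 3 is 1100 nM, with a range from 400 nM to 3500 nM.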

Compound 3, concentration for total growth inhibition: 720 nM
Estimate against measurement, compound 3: 1.5-fold (0.18 log units) above; measured number inside the range.
By their numbers in this assay, from the lowest: compounds 3 and 2 (each within the scatter of the next); then compound 1.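

At this saturated ring carbon, 4-(dimethylamino)phenyl replaces 2-hydroxyphenyl with a 1.3-fold lower number from compound 2 to compound 3 (0.11 log units; within the scatter) in this assay, so the two arms cannot be told apart here. The position therefore accepts an arm with no hydrogen-bond donor and more heavy atoms, at least on the bromo analogue. Nothing available explains why the two arms read alike. Still open, from the compounds shown here alone, is whether the same swap gives a similar result without the bromo, on the core of compound 1. Also open, going by these compounds, is how a carboxylic acid or a longer chain at this position would read.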